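Chain shape at the ether oxygen of an aminoquinoline-type core

A few compounds are considered here, and "the series" means these few. Any claim that something is new, unique, unknown or untested is made for them only; others in the source may bear on it.

Compound 1 `CC(CC(C)(C)C)Oc1cccc2cccnc12`: in an assay on cells with melanin-concentrating hormone receptor 1 (Homo sapiens) as the target, read by radioligand binding (on this read-out higher numbers stand for weaker inhibition and lower numbers for stronger inhibition), compound 1 gives > 2000 nM, a limit of the assay.
Compound 2 `CCCC(C)Oc1cccc2ccc(N)nc12`: in this assay compound 2 gives 105 nM.
Compound 3 `CC(COC(C)(C)C)Oc1cccc2ccc(N)nc12`: in this assay compound 3 gives 306 nM.

Compound 2 stands lowest of the two numbers given; compound 3 is the nearest, and compound 1 is known only as a limit (the limit of > 2000 nM in this assay, at which 1 of the 3 values shown sits). Compound 4 `CC(C)(C)CCOc1cccc2ccc(N)nc12` differs from compound 2 in one place: 3,3-dimethylbutyl in place of 1-methylbutyl on an oxygen on an aromatic ring. Within the data shown here, the one measured step that bears on a change in this chain is a 2.9-fold higher number from compound 2 to compound 3 (0.46 log units; beyond the scatter), a modest weakening when a bulkier end is placed on the chain. Among the measured compounds shown here, compound 4 likewise carries a bulkier end but loses the branch next to the oxygen, a combination no measured pair shows directly. A step of similar modest size in the weakening direction is therefore expected, so that the step of a 2.4-fold higher number from compound 2 to compound 4 (0.38 log units; beyond the scatter) is the estimate. Compound 4 is expected to give about 250 nM in this assay, within 100 nM to 700 nM.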

Compound 4, half-maximal inhibitory concentration: 201 nM
Estimate against measurement, compound 4: 1.2-fold (0.09 log units) above; the measured number falls inside the stated range.
By their numbers in this assay, from the lowest: compounds 2, 4 and 3 (each within the scatter of the next, the first and the last beyond it). At a limit, above all of these: compound 1.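

In this assay the exchange of 1-methylbutyl for 3,3-dimethylbutyl on an oxygen on an aromatic ring gives a 1.9-fold higher number from compound 2 to compound 4 (0.28 log units; within the scatter) and so does not separate these two chains. Among these compounds, the only step on this chain known before was a 2.9-fold higher number from compound 2 to compound 3 (0.46 log units; beyond the scatter) and it lay beyond the scatter, whereas here a chain of 6 heavy atoms with a different branching pattern takes the place of one of 5 and stays within it. Nothing measured here gives a reason for this result.

On these data alone, how a chain ending in an amine, a carboxylic acid or a cyclohexyl ring would read on the same oxygen stays open. So does the part played by the amino group on the core, which compound 1 lacks while also differing in its chain and being known only as a limit.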